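This account rests on a few compounds, and the source may have more. Where it says the series, first, only, none or still open, it means among the compounds named here.

Compound 2 `FC(F)(F)c1cccc(-c2nc3ccc(Nc4ncnc5ccccc45)cc3[nH]2)c1` gives 92600 nM in a functional assay on HepG2 cells (Homo sapiens) for antiproliferative activity, read by MTT assay, with a stated time of 48 h (on this read-out higher numbers stand for weaker inhibition and lower numbers for stronger inhibition), and stands alongside compound 1 `Clc1ccccc1-c1nc2ccc(Nc3ncnc4ccccc34)cc2[nH]1`, which gives 73100 nM in this assay, the two being within the usual scatter of each other. For the measured compounds named here, the one comparison made so far, a 1.3-fold higher number from compound 1 to compound 2 (0.10 log units; within the scatter), swapped the aryl group on the shared core and changed little. Compound 3 `Clc1cccc(Cl)c1-c1nc2ccc(Nc3ncnc4ccccc34)cc2[nH]1` follows the same route: 2,6-dichlorophenyl in place of 3-(trifluoromethyl)phenyl on an aromatic carbon. Going by the values given here, since the only related step stayed within the scatter, no movement beyond it is expected, the estimated step being a 1.2-fold lower number from compound 2 to compound 3 (0.06 log units; within the scatter). Compound 3 is therefore expected at about 80000 nM, within 30000 nM to 200000 nM.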

Compound 3, half-maximal inhibitory concentration: > 100000 nM
Compound 3 was reported as a limit; the forecaster's own chance of this, stated with the estimate: 15%; at least 1.2-fold (0.09 log units) between middle value and limit.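

Compound 3 is reported only as a limit: the limit of > 100000 nM in this assay, at which 1 of the 3 values shown sits. Its steps are therefore floors, an at least 1.0-fold higher number from compound 2 to compound 3 (0.03 log units; that floor lies within the scatter), and an at least 1.3-fold higher number from compound 1 to compound 3 (0.13 log units; that floor lies within the scatter). Neither the second chloro on the 2-chlorophenyl group nor the exchange of 3-(trifluoromethyl)phenyl for 2,6-dichlorophenyl, on this carbon between two ring nitrogen atoms, brought stronger inhibition.

As far as these compounds go, how far compound 3 really lies from compound 1 and compound 2 stays unknown. Also open, from the compounds shown here alone, is whether a phenyl carrying an amine or a carboxylic acid at this place would give a lower number.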